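Shifting a Hydroxyl Group on the Third Phenyl Ring

The source may hold more compounds than are shown below. What is called first, only, known or untested is meant among the compounds shown, and "the series" means these compounds.

Compound 1 `Oc1ccc(-c2cc(-c3cccc(O)c3)nc(-c3cccc(O)c3)c2)cc1` carries three hydroxyphenyl groups on a shared core. In a functional assay on DU-145 cells (Homo sapiens) for cytotoxicity, read by CCK-8 assay, with a stated time of 4 days (on this read-out higher numbers stand for weaker inhibition and lower numbers for stronger inhibition), compound 1 gives 1760 nM, the lower of the two numbers recorded so far. Compound 2 `Oc1cccc(-c2cc(-c3cccc(O)c3)nc(-c3cccc(O)c3)c2)c1` gives 4040 nM, and the step of a 2.3-fold higher number from compound 1 to compound 2 (0.36 log units; beyond the scatter) shows that exchanging a 4-hydroxyphenyl for a 3-hydroxyphenyl weakens the effect modestly.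

Compound 3 `Oc1ccc(-c2cc(-c3cccc(O)c3)nc(-c3ccccc3O)c2)cc1` is built from compound 1 by a change of the same kind on another ring: 2-hydroxyphenyl in place of 3-hydroxyphenyl on an aromatic carbon. Among the measured compounds shown here, no measured step covers this exact exchange; only a 2.3-fold higher number from compound 1 to compound 2 (0.36 log units; beyond the scatter) speaks to what happens when a hydroxyl is relocated on one of the three rings, and that step went toward a higher number. For the measured compounds named here, a step of similar modest size in the same direction is therefore expected, a 1.6-fold higher number from compound 1 to compound 3 (0.20 log units; within the scatter), although an outcome within the scatter would not be surprising given that only one comparison is available. Compound 3 is estimated at 2800 nM, with a range from 1100 nM to 7000 nM.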

Compound 3, half-maximal inhibitory concentration: 3420 nM
Compound 3: the middle estimate sits 1.2-fold (0.09 log units) below what was measured, within the range that was stated.
By their numbers in this assay, from the lowest: compounds 1, 3 and 2 (each within the scatter of the next, the first and the last beyond it).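

Moving the hydroxyl around this ring, so that a 2-hydroxyphenyl group replaces a 3-hydroxyphenyl group on the aromatic carbon next to the ring nitrogen, gives a step that cannot be told apart from ordinary repeat variation in this assay: a 1.9-fold higher number from compound 1 to compound 3 (0.29 log units; within the scatter). The earlier comparison concerned a different ring, and its step, a 2.3-fold higher number from compound 1 to compound 2 (0.36 log units; beyond the scatter), lay beyond the scatter, so across these two pairs, relocating a hydroxyl does not always produce a clear difference. No measurement here offers an explanation for either result.

The compounds shown leave open whether a hydroxyl is needed at all at this place, and a methoxy group or an amine on the same phenyl ring would help to test that. Also open, from the compounds shown here alone, is how a 4-hydroxyphenyl group would read next to the ring nitrogen, which would complete the set of hydroxyl positions on this ring.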